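Notes on the oxazolone urea series: toward compound 4

The source may hold more compounds than are shown below. What is called first, only, known or untested is meant among the compounds shown, and "the series" means these compounds.

In an assay on HEK293 cells for inhibition of acid ceramidase (Homo sapiens), read by fluorescence, with stated times of 10 min and 3 h (a lower number here means a stronger inhibitor, a higher number a weaker inhibitor), compound 3 `CC(C)CN1CCN(c2ccc3c(c2)oc(=O)n3C(=O)NCCCCc2ccccc2)CC1` gives 127 nM, the second highest of the three numbers. Its nearest neighbour is compound 1 `CC(C)CN1CCC(c2ccc3c(c2)oc(=O)n3C(=O)NCCCCc2ccccc2)CC1` at 120 nM; the furthest is compound 2 `CC(C)CNC(=O)n1c(=O)oc2cc(C3CCN(C)CC3)ccc21` at 166 nM; both gaps lie within the scatter. Among the measured compounds shown here, the one step that bears directly on the ring change, a 1.1-fold higher number from compound 1 to compound 3 (0.02 log units; within the scatter), was within the scatter as well. Compound 4 `CN1CCC(c2ccc3c(c2)oc(=O)n3C(=O)NCCCCc2ccccc2)CC1` carries 1-methylpiperidin-4-yl in place of 4-isobutylpiperazin-1-yl on an aromatic carbon. Compound 2 holds the same 1-methylpiperidin-4-yl group on its core, though with a different urea substituent, so it does not give a clean step. With no change beyond the scatter seen so far, the step from compound 3 to compound 4 in this assay is expected to be small, a 1.0-fold higher number from compound 3 to compound 4 (0.01 log units; within the scatter). Compound 4 is therefore estimated at 130 nM, within 60 nM to 300 nM.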

Compound 4, half-maximal inhibitory concentration: 129 nM
Beside the measured number, compound 4's estimate is 1.0-fold (0.00 log units) above it, within the range that was stated.
By their numbers in this assay, from the lowest: compounds 1, 3, 4 and 2 (each within the scatter of the next).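

In this assay 1-methylpiperidin-4-yl in place of 4-isobutylpiperazin-1-yl on the aromatic carbon gives a 1.0-fold higher number from compound 3 to compound 4 (0.01 log units; within the scatter) and so changes ring and nitrogen substituent together without a step beyond the scatter. Taken singly, hydrogen in place of isopropyl on the chain carbon bound to the ring amine nitrogen gives a 1.1-fold higher number from compound 1 to compound 4 (0.03 log units; within the scatter) while 3-phenylpropyl in place of isopropyl on the chain carbon bound to the amide-type nitrogen gives a 1.3-fold lower number from compound 2 to compound 4 (0.11 log units; within the scatter) and neither step leaves the scatter. Nothing available accounts for this flatness.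

As far as these compounds go, how a morpholin-4-yl group or a carboxylic acid on this aromatic carbon would read stays open, as does a longer chain on the amide-type nitrogen.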